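This account rests on a few compounds, and the source may have more. Where it says the series, first, only, none or still open, it means among the compounds named here.

Measured in a physicochemical assay for lipophilicity, measured as octanol-water partition, at pH 7.4; on this read-out lower numbers stand for lower lipophilicity and higher numbers for higher lipophilicity:
- compound 1 `CC(C)c1noc(N2CCC(Oc3cc(N4CCc5cc(N6CC(O)CCC6=O)ccc54)ncn3)CC2)n1`: 2.6
- compound 2 `CC(C)c1noc(N2CCC(Oc3cc(N4CCc5cc(N6CCCS6(=O)=O)ccc54)ncn3)CC2)n1`: 3.2
- compound 3 `CC(C)c1noc(N2CCC(Oc3cc(N4CCc5cc([S+]([O-])CCO)ccc54)ncn3)CC2)n1`: 2.7

Compound 3 stands level with compound 1, with a number 0.10 log units higher from compound 1 to compound 3 (within the scatter). It sits under compound 2, with a number 0.50 log units lower from compound 2 to compound 3 (beyond the scatter).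

Next in the series is compound 4 `CC(C)c1noc(N2CCC(Oc3cc(N4CCc5cc(N6CCC(O)CC6=O)ccc54)ncn3)CC2)n1`, with the change (a group of 8 heavy atoms (5 carbon, 1 nitrogen, 2 oxygen; one six-membered non-aromatic ring with 1 hetero atom) in place of a group of 5 heavy atoms (2 carbon, 2 oxygen, 1 sulfur; no ring), on an aromatic carbon). The entering group is 4-hydroxy-2-oxopiperidin-1-yl, on the same aromatic carbon.

The most relevant measurement is a number 0.10 log units higher from compound 1 to compound 3 (within the scatter), which links a group of the same counted make-up as the entering one to the group that leaves here, in the opposite sense. Going by the values given here, the ring in compound 1 is not identical to the entering ring, and no measured step covers that difference. The other measured step from compound 1, a number 0.60 log units higher from compound 1 to compound 2 (beyond the scatter), shows that changes at this place can exceed the scatter, but it involves a different ring.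

No step beyond the scatter is therefore expected in this assay, the estimate being a number 0.10 log units lower from compound 3 to compound 4 (within the scatter). The expected value for compound 4 is 2.6, with an estimated range of 2.2 to 3.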

Compound 4, distribution coefficient: 2.8
Compound 4: the middle estimate sits 0.20 log units below what was measured, within the range that was stated.
By their numbers in this assay, from the lowest: compounds 1, 3 and 4 (each within the scatter of the next); then compound 2.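

Moving the hydroxy group within the ring, from 5-hydroxy-2-oxopiperidin-1-yl to 4-hydroxy-2-oxopiperidin-1-yl on the same aromatic carbon, gives in this assay a number 0.20 log units higher from compound 1 to compound 4 (within the scatter) and so does not separate the two ring placements. The open-chain sulfur group and the 4-hydroxy ring are likewise not separated, with a number 0.10 log units higher from compound 3 to compound 4 (within the scatter) as the reading, whereas the five-membered sulfur-containing ring remains apart, with a number 0.40 log units lower from compound 2 to compound 4 (beyond the scatter) as the reading. No supporting data bear on why these readings fall as they do.

Going by these compounds, the unsubstituted 2-oxopiperidin-1-yl group remains open, so the contribution of the hydroxy group at either ring placement cannot be stated. Also open, on these data alone, is where an amine or a carboxylic acid on this aromatic carbon would fall relative to these four compounds.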